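Pyridin-3-yl for 1H-benzimidazol-1-yl in compound 1

The compounds below may be only part of what the source reports. "The series", "measured", "known", "first", "only" and "open" are said of these compounds alone.

Compound 1 `CCN(c1ccc(C#N)c(Cl)c1)c1cc(-n2cnc3ccccc32)ccc1C` is the only entry with a numeric result: in a functional assay on VCaP cells (Homo sapiens) for antiproliferative activity, read by CCK-8 assay, with a stated time of 6 days (a higher number here means a weaker inhibitor, a lower number a stronger inhibitor), compound 1 gives 8560 nM. Compound 2 `N#Cc1ccc(N2CCc3cc(-c4cnc5ccccc5c4)ccc3C2)cc1C(F)(F)F` reaches only a limit in this assay, > 30000 nM, which is the limit of > 30000 nM in this assay, at which 1 of the 3 values shown sits. Compound 3 `N#Cc1ccc(N2CCc3cc(-c4cncnc4)ccc3C2)cc1C(F)(F)F` has no numeric result in this assay; for compound 3 the entry reads "not determined" (no result reported). As far as these compounds go, compound 4 `CCN(c1ccc(C#N)c(Cl)c1)c1cc(-c2cccnc2)ccc1C` is untested; it differs from compound 1 by pyridin-3-yl in place of 1H-benzimidazol-1-yl on an aromatic carbon. Among the measured compounds shown here, no step between measured compounds is available, so the expected size of this change in this assay rests on compound 1 alone. A small step toward weaker inhibition, within or just beyond the scatter, is expected: a 1.4-fold higher number from compound 1 to compound 4 (0.15 log units; within the scatter). Compound 4 is estimated at 12000 nM, in the range 3500 nM to 30000 nM, with a real chance that only a limit is returned.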

Compound 4, half-maximal inhibitory concentration: 1270 nM
Beside the measured number, compound 4's estimate is 9.4-fold (0.98 log units) above it; the whole stated range lies above it.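

The group on the aromatic carbon para to the methyl group clearly affects the result in this assay, which compound 1 alone could not show: pyridin-3-yl in place of 1H-benzimidazol-1-yl gives a 6.7-fold lower number from compound 1 to compound 4 (0.83 log units; beyond the scatter). The two-ring group is therefore not required at this place, and a single six-membered aromatic ring with one nitrogen serves better in this pair. Nothing shown explains this step.

This is a single pair, so its size may not carry over to another core. As far as these compounds go, whether phenyl, a carboxylic acid or an aminomethyl group at this place would extend the gain remains open.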